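Dropping one methyl from compound 2

The source may hold more compounds than are shown below. What is called first, only, known or untested is meant among the compounds shown, and "the series" means these compounds.

Measured so far in a functional assay on PC-3 cells (Homo sapiens) for inhibition; on this read-out higher numbers stand for weaker inhibition and lower numbers for stronger inhibition:
compound 1 `CCn1c(=O)/c(=C2\Sc3ccccc3N2C)s/c1=C\c1ccncc1Nc1ccccc1F`: 360 nM
compound 2 `CCn1c(=O)/c(=C2\Sc3ccccc3N2C)s/c1=C\c1ccncc1Nc1cc(C)ccc1C`: 2000 nM

Among the compounds with values here, compound 2 stands with the highest of the two numbers in this assay; its nearest neighbour is compound 1, and the only measured step, a 5.6-fold higher number from compound 1 to compound 2 (0.74 log units; beyond the scatter), separates them by a modest amount that lies beyond the scatter. Compound 3 `CCn1c(=O)/c(=C2\Sc3ccccc3N2C)s/c1=C\c1ccncc1Nc1ccccc1C` has not yet been measured. It differs from compound 2 in one place: hydrogen in place of methyl on an aromatic carbon.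

Within the data shown here, no measured step removes a single methyl in this way. Among the measured compounds shown here, the one step at hand exchanges the whole 2,5-dimethylphenyl for a 2-fluorophenyl, so it bears only indirectly on the change to compound 3. Because compound 1 gives 360 nM and compound 2 gives 2000 nM while compound 3 keeps the 2-methylphenyl part of compound 2 and loses only the second methyl, compound 3 sits between them in structure and a number between their values is expected. The estimated step is a 2.2-fold lower number from compound 2 to compound 3 (0.35 log units; beyond the scatter), smaller than the measured one. For compound 3 the expected value in this assay is 900 nM, with a range from 300 nM to 2500 nM.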

Compound 3, half-maximal inhibitory concentration: 1200 nM
Estimate against measurement, compound 3: 1.3-fold (0.12 log units) below; the measured number falls inside the stated range.
By their numbers in this assay, from the lowest: compound 1; then compounds 3 and 2 (each within the scatter of the next).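

In this assay, hydrogen in place of the methyl that stands meta to a large group and para to a methyl group gives a 1.7-fold lower number from compound 2 to compound 3 (0.22 log units; within the scatter), so at this position the exchange of methyl for hydrogen leaves the two compounds indistinguishable on this read-out. The change that does register is methyl in place of fluoro, which gives a 3.3-fold higher number from compound 1 to compound 3 (0.52 log units; beyond the scatter), and this step alone accounts for the larger part of the earlier gap of a 5.6-fold higher number from compound 1 to compound 2 (0.74 log units; beyond the scatter), a gap that could not be divided while the whole aryl group changed in a single step. Nothing available gives a reason for either step.

On these data alone, at the position of the removed methyl only methyl and hydrogen appear, so it remains open whether a larger or different group there, such as a methoxy, a chlorine or a carboxylic acid, would shift the number beyond the scatter. As far as these compounds go, it also remains open where a plain phenyl, with hydrogen in place of the fluoro of compound 1, would fall relative to the fluoro and methyl compounds.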